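From chloro to isopropoxy on compound 1

This account rests on a few compounds, and the source may have more. Where it says the series, first, only, none or still open, it means among the compounds named here.

compound 1 `OC(c1ccc(Cl)cc1)(c1cccnc1)c1ccccc1Cl` – 61300 nM
compound 2 `COC(c1ccc(Cl)cc1)(c1cccnc1)c1ccccc1Cl` – 58700 nM
compound 3 `[O-][n+]1cncc(C(O)(c2ccc(Cl)cc2)c2ccccc2Cl)c1` – > 100000 nM as a limit of the assay, not a number

In an ADME assay on L6 cells (Rattus norvegicus) for cytotoxicity, read by resazurin assay, with a stated time of 72 h (on this read-out lower numbers stand for stronger inhibition and higher numbers for weaker inhibition), compound 1 gives 61300 nM and sits within the scatter of compound 2. Compound 4 `CC(C)Oc1ccccc1C(O)(c1ccc(Cl)cc1)c1cccnc1` is still unmeasured and differs from compound 1 by one change isopropoxy in place of chloro on an aromatic carbon on an aromatic carbon, ortho to a large group.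

Two measured steps start at compound 1. Putting methyl in place of hydrogen on the oxygen gives a 1.0-fold lower number from compound 1 to compound 2 (0.02 log units; within the scatter) and stays within the scatter. Exchanging the aromatic ring with one hetero atom for the group with two gives an at least 1.6-fold higher number from compound 1 to compound 3 (0.21 log units; that floor lies within the scatter) as a floor only, and that floor also lies within the scatter. Neither step touches the place that changes in compound 4, so their guidance is indirect. Going by the step of a 1.0-fold lower number from compound 1 to compound 2 (0.02 log units; within the scatter) no change beyond the scatter is expected in this assay in either direction. The estimated step is a 1.1-fold lower number from compound 1 to compound 4 (0.05 log units; within the scatter) and its direction is uncertain. Compound 4 is expected at 55000 nM with a range from 25000 nM to 100000 nM in this estimate.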

Compound 4, half-maximal inhibitory concentration: 48300 nM
Estimate against measurement, compound 4: 1.1-fold (0.06 log units) above, and the stated range covers the measured number.
By their numbers in this assay, from the lowest: compounds 4, 2 and 1 (each within the scatter of the next). At a limit, above all of these: compound 3.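

In this assay, this position on the ring of carbon only, ortho to a large group, takes isopropoxy in place of chloro with a 1.3-fold lower number from compound 1 to compound 4 (0.10 log units; within the scatter), even though isopropoxy brings 1 hydrogen-bond acceptor where chloro had no acceptor. Among these compounds, the earlier steps changed other places, so this is the first reading at this position, and it shows that this swap leaves the number within the scatter. Compound 4 also gives a readable number, so this change does not carry the compound to the limit of the assay: the limit of > 100000 nM in this assay, at which 1 of the 4 values shown sits.

With only chloro and isopropoxy shown at this position, no trend can be drawn from them. Going by these compounds, whether an amine, a carboxylic acid or a longer chain placed here would move the number beyond the scatter remains open.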